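The source may report more compounds than this note shows. Statements on the series, on what has been measured and on what is new or still open speak of the compounds shown alone.

In a functional assay on PANC-1 cells (Homo sapiens) for inhibition, read by MTT assay, with a stated time of 24 h, tested at 10 uM (a higher number here means more inhibition at the concentration tested (going by the name of the read-out), a lower number less inhibition), compound 1 `CC(C)=CCC1Cc2c(OCc3ccccc3)cc(=O)n(CCCO)c2CC1(C)C` gives 11.1%. Compound 2 `CC(C)=CCC1Cc2c(OC(=O)Nc3ccccc3F)cc(=O)n(CCCO)c2CC1(C)C` gives 0% in this assay, the lowest of the two numbers shown, and the only measured step is a number 11.1 percentage points lower from compound 1 to compound 2 (beyond the scatter). Compound 3 `CC(C)=CCC1Cc2c(OC(=O)Nc3ccc(F)c(Cl)c3)cc(=O)n(CCCO)c2CC1(C)C` differs from compound 2 by 3-chloro-4-fluorophenyl in place of 2-fluorophenyl on an amide-type nitrogen. Within the data shown here, no measured step changes the group on the amide-type nitrogen; the one step available concerns the benzyl-to-carbamoyl change on the ring oxygen and bears only loosely on this one. Given the nothing-left-to-lose value of compound 2, the step of a number 3 percentage points higher from compound 2 to compound 3 (within the scatter) is expected to stay within the scatter. Compound 3 is estimated at 3%, range 0% to 12% in this assay.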

Compound 3, a percentage reported as inhibition, at one concentration (the size of the read-out at that concentration, not a potency): 0%
The estimate for compound 3 lay 3 percentage points above the measured number; the measured number falls inside the stated range.
By their numbers in this assay, from the lowest: compounds 2 and 3 (each within the scatter of the next); then compound 1.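

Within this assay, 3-chloro-4-fluorophenyl in place of 2-fluorophenyl on the amide-type nitrogen gives no change at the digits printed from compound 2 to compound 3 (within the scatter), so this change of aryl group brings no readable inhibition. The second carbamoyl group repeats the loss seen on replacing benzyl, with a number 11.1 percentage points lower from compound 1 to compound 3 (beyond the scatter), so that loss is not confined to the 2-fluorophenyl case. Nothing available bears on why these numbers fall as they do.

Open, going by these compounds, is whether an amine or a carboxylic acid on the group carried by the amide-type nitrogen would restore any inhibition. A longer chain between that nitrogen and the phenyl ring is equally untested in the compounds shown.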